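Methylation of the Ring Nitrogen in a Paw Edema Series

This account rests on a few compounds, and the source may have more. Where it says the series, first, only, none or still open, it means among the compounds named here.

Of the compounds shown here, three built on one shared core have been measured in a functional assay on the whole organism (strain albino) for inhibition, with Rattus norvegicus as the target, read by paw edema, with stated times of 1 h and 3 h, at a dose of 100 mg/kg by the oral route; a lower number here means a weaker effect, a higher number a stronger effect of the compound at the dose given. Compound 1 `N#Cc1c(-c2ccc(Cl)cc2)nc(SCC(=O)Nn2c(COc3ccc(Cl)cc3Cl)nc3ccccc3c2=O)[nH]c1=O` gives 64.9% in this assay. Compound 2 `N#Cc1c(-c2ccc(O)cc2)nc(SCC(=O)Nn2c(COc3ccc(Cl)cc3Cl)nc3ccccc3c2=O)[nH]c1=O` gives 68.4%, and compound 3 `O=C(CSc1nc(-c2ccc(Cl)cc2)c(C(=O)O)c(=O)[nH]1)Nn1c(COc2ccc(Cl)cc2Cl)nc2ccccc2c1=O` gives 61.4%. Compound 1 thus stands second highest of the three numbers: its nearest neighbour is compound 2, with the step of a number 3.5 percentage points higher from compound 1 to compound 2 (within the scatter) lying within the scatter, and its furthest is compound 3, with the step of a number 3.5 percentage points lower from compound 1 to compound 3 (within the scatter) also within the scatter. Neither exchange on an aromatic carbon, hydroxy for chloro or carboxy for cyano, moved the read-out further than repeated measurement would.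

Compound 4 `Cn1c(SCC(=O)Nn2c(COc3ccc(Cl)cc3Cl)nc3ccccc3c2=O)nc(-c2ccc(Cl)cc2)c(C#N)c1=O` has not yet been measured in this assay. It differs from compound 1 by methyl in place of hydrogen on an aromatic nitrogen. Going by the values given here, no measured step touches this ring nitrogen; the two known steps concern an aromatic carbon and both sit within the scatter. There is therefore no ground for a shift in either direction, and the step expected in this assay is a number 1.9 percentage points lower from compound 1 to compound 4 (within the scatter), within the scatter. The estimated value for compound 4 is 63%, with an expected range from 50% to 75%.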

Compound 4, a percentage reported as inhibition, in the whole organism at one dose (the size of the read-out at that dose, not a potency): 73.7%
Compound 4: middle estimate off by 10.7 percentage points, on the low side; the range from low to high includes it.
By their numbers in this assay, from the lowest: compounds 3, 1, 2 and 4 (each within the scatter of the next, the first and the last beyond it).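

Going by these compounds alone, the step at the ring nitrogen, a number 8.8 percentage points higher from compound 1 to compound 4 (within the scatter), is the first measured at this position, and like the two earlier steps on aromatic carbons it does not leave the scatter of this assay. It shows that the hydrogen on this aromatic nitrogen is not required for the read-out: compound 4 carries a methyl there and has no such hydrogen, yet its effect at the dose given cannot be told apart from that of compound 1. No measurement at hand bears on what this exchange does beyond the read-out itself, so the result stands without an explanation.

From the compounds shown here alone, whether an ethyl group, a longer chain or an acetyl group on the same nitrogen would also be tolerated remains open, and a single methyl cannot show whether the size of the group matters at this position. It is also open whether the methyl would give a similar result alongside the hydroxy group of compound 2 or the carboxylic acid of compound 3, and, with only one dose shown, how the potency of compound 4 compares with that of compound 1.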